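From 4-fluorophenyl to 2-(trifluoromethyl)phenyl on a sulfur

A few compounds are considered here, and "the series" means these few. Any claim that something is new, unique, unknown or untested is made for them only; others in the source may bear on it.

Compound 1 `CC(O)(CSc1cccc(S(F)(F)(F)(F)F)c1)C(=O)Nc1ccc(C#N)c(C(F)(F)F)c1` gives 32700 nM
Compound 2 `CC(O)(CSc1ccc(F)cc1)C(=O)Nc1cccc(S(F)(F)(F)(F)F)c1` gives 38500 nM

Both values come from a functional assay on DU-145 cells (Homo sapiens) for antiproliferative activity, read by propidium iodide staining, with a stated time of 96 h (on this read-out lower numbers stand for stronger inhibition and higher numbers for weaker inhibition), and lie within the scatter of each other, so compound 2 cannot be told apart from compound 1. Compound 3 `CC(O)(CSc1ccccc1C(F)(F)F)C(=O)Nc1cccc(S(F)(F)(F)(F)F)c1` carries 2-(trifluoromethyl)phenyl in place of 4-fluorophenyl on a sulfur. Within the data shown here, no step between measured compounds is available as a guide, and no shift beyond the scatter is expected in this assay for this change. An estimated 1.3-fold lower number from compound 2 to compound 3 (0.11 log units; within the scatter) stays within the scatter. Compound 3 is estimated at 30000 nM (range 13000 nM to 70000 nM).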

Compound 3, half-maximal inhibitory concentration: 15800 nM
Beside the measured number, compound 3's estimate is 1.9-fold (0.28 log units) above it; measured number inside the range.
By their numbers in this assay, from the lowest: compound 3; then compounds 1 and 2 (each within the scatter of the next).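

In this assay, among these compounds, placing 2-(trifluoromethyl)phenyl in place of 4-fluorophenyl on a sulfur gives a 2.4-fold lower number from compound 2 to compound 3 (0.39 log units; beyond the scatter) and so provides the first modest step beyond the scatter in this set. It shows that the number can respond to the group on this sulfur, though one step cannot define a trend. Nothing available accounts for the step. Still open, from the compounds shown here alone, is whether a plain phenyl, a pyridine or a cyclohexyl on the sulfur would shift the number further. Going by these compounds, whether the same exchange would carry over to the core of compound 1 also remains open.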